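This account rests on a few compounds, and the source may have more. Where it says the series, first, only, none or still open, it means among the compounds named here.

Working notes on the naphthyl-hydroxy amidrazone series, cytotoxicity arm.

The series shares one core and varies the aryl group on the carbon with a double bond to nitrogen. Compound 1 `N/C(CC(O)c1cccc2ccccc12)=N\N=C\c1ccc(F)cc1F` carries a 2,4-difluorophenyl there; compound 3 `N/C(CC(O)c1cccc2ccccc12)=N\N=C\c1ccc(F)c(F)c1` a 3,4-difluorophenyl; compound 2 `CCC/C(=N\N=C(/N)CC(O)c1cccc2ccccc12)c1ccccc1` a butanone-derived phenyl variant on the same position.

In an ADME assay on L6 cells (Rattus norvegicus) for cytotoxicity, read by resazurin assay, with a stated time of 72 h (a higher number here means a weaker inhibitor, a lower number a stronger inhibitor), compound 1 gives 4200 nM, compound 3 gives 17000 nM and compound 2 gives 29000 nM. Compound 1 therefore stands with the lowest number of the three, with compound 3 nearest and compound 2 furthest; both gaps lie beyond the scatter.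

Compound 4 `N/C(CC(O)c1cccc2ccccc12)=N\N=C\c1cccc(Br)c1` is not yet measured. Its change from compound 1: 3-bromophenyl in place of 2,4-difluorophenyl on a carbon with a double bond to nitrogen. Within the data shown here, the one measured step that bears on an aryl change at this position is a 4.0-fold higher number from compound 1 to compound 3 (0.61 log units; beyond the scatter), a modest move toward weaker cytotoxicity when the ring substitution shifts. The step from compound 2 is a larger change and does not isolate the aryl group.

On that basis a modest rise in number is expected for compound 4 in this assay, about a 2.1-fold higher number from compound 1 to compound 4 (0.33 log units; beyond the scatter), with the scatter leaving room for no shift at all. The expected value for compound 4 is 9000 nM, within a range of 3000 nM to 27000 nM.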

Compound 4, half-maximal inhibitory concentration: 3900 nM
Compound 4: middle estimate off by 2.3-fold (0.36 log units), on the high side, and the stated range covers the measured number.
By their numbers in this assay, from the lowest: compounds 4 and 1 (each within the scatter of the next); then compounds 3 and 2 (each within the scatter of the next).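

In this assay, the new result changes how the earlier aryl step reads: a 4.0-fold higher number from compound 1 to compound 3 (0.61 log units; beyond the scatter) could have suggested that moving away from the 2,4-difluorophenyl raises the number at this position, but a 1.1-fold lower number from compound 1 to compound 4 (0.03 log units; within the scatter) shows that a 3-bromophenyl on the same carbon cannot be told apart from the 2,4-difluorophenyl. The 3-bromophenyl also separates from the 3,4-difluorophenyl, with a 4.4-fold lower number from compound 3 to compound 4 (0.64 log units; beyond the scatter), so of these three aryl groups it is the 3,4-difluorophenyl that stands apart, while compound 1 and compound 4 sit together. Replacing the 2,4-difluorophenyl therefore does not by itself shift the number, and among compounds 1, 3 and 4 the outcome depends on which aryl group enters rather than on the departure of the 2,4-difluorophenyl.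

Going by these compounds, it remains open whether an aryl group carrying an amine or a carboxylic acid at this carbon would stay level with compound 1 and compound 4 or would move toward compound 3. Nothing available explains why compound 3 separates from the other two, and no supporting data bear on this result.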